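Nitro in Place of Methoxy on a Shared Core

The source may hold more compounds than are shown below. What is called first, only, known or untested is meant among the compounds shown, and "the series" means these compounds.

Compound 1 `COc1ccc2[nH]c(-c3nc(-c4ccccc4)no3)cc2c1`: in a functional assay on Jurkat cells (Homo sapiens) for antiproliferative activity, read by WST assay, with a stated time of 72 h (on this read-out lower numbers stand for stronger inhibition and higher numbers for weaker inhibition), compound 1 gives > 50000 nM, a limit of the assay.
Compound 2 `Clc1ccc(-c2noc(-c3cc4ccccc4[nH]3)n2)cc1`: in this assay compound 2 gives > 50000 nM, again only a limit.
Compound 3 `COc1ccc2[nH]c(-c3nc(-c4ccc(Cl)cc4)no3)cc2c1`: in this assay compound 3 gives > 50000 nM, also a limit.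

Compound 3 thus stands at the assay limit, where all three values sit (the limit of > 50000 nM in this assay, at which 3 of the 3 values shown sit). The two steps leading to it, a step that the two limits leave unreadable from compound 1 to compound 3 and a step that the two limits leave unreadable from compound 2 to compound 3, cannot be sized. Compound 4 `O=[N+]([O-])c1ccc2[nH]c(-c3nc(-c4ccc(Cl)cc4)no3)cc2c1` differs from compound 3 by nitro in place of methoxy on an aromatic carbon. For the measured compounds named here, no measured step covers this exchange. Compound 4 is therefore expected to stay near the limit, and the step of an at least 1.1-fold lower number from compound 3 to compound 4 (0.04 log units; that floor lies within the scatter) is estimated as nothing beyond the scatter. For compound 4 the estimate in this assay is 45000 nM, between 8000 nM and 100000 nM.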

Compound 4, half-maximal inhibitory concentration: > 50000 nM
Compound 4 was reported as a limit; the forecaster's own chance of this, stated with the estimate: 75%; at least 1.1-fold (0.04 log units) between middle value and limit.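

Compound 4, like compound 2 and compound 3, sits at a limit, so neither step to compound 4 can be read: the limit of > 50000 nM in this assay, at which 4 of the 4 values shown sit.
In this assay the compounds shown leave open whether any change on the shared core gives a number rather than a limit.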